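Swapping the Outer Aryl Group for a Styryl Extension

The compounds below may be only part of what the source reports. "The series", "measured", "known", "first", "only" and "open" are said of these compounds alone.

Compound 2 `COC(=O)/C=C/c1cccc(N(Cc2ccc(-c3ccc(SC)cc3)cc2)C(=O)C2CCCCC2)c1` is one of two compounds tested in an assay on isolated protein with Bile acid receptor (Homo sapiens) as the target; on this read-out lower numbers stand for an effect already at smaller amounts and higher numbers for an effect only at larger amounts of compound. In this assay compound 2 gives 69 nM, the lowest of the two numbers, while compound 1 `CCOc1cccc(-c2ccc(CN(C(=O)C3CCCCC3)c3cccc(/C=C/C(=O)OC)c3)cc2)c1` gives 147 nM in this assay. Among the measured compounds shown here, the only measured step, a 2.1-fold lower number from compound 1 to compound 2 (0.33 log units; beyond the scatter), exchanges one outer aryl group for another. Compound 3 `COC(=O)/C=C/c1cccc(N(Cc2ccc(/C=C/c3ccc(OC)cc3)cc2)C(=O)C2CCCCC2)c1` is not yet measured. It differs from compound 2 in one place: 2-(4-methoxyphenyl)ethenyl in place of 4-(methylsulfanyl)phenyl on an aromatic carbon. For the measured compounds named here, this again replaces the same outer group, so the step from compound 1 to compound 2 is the only guide, and it did not move the number far. Because that step a 2.1-fold lower number from compound 1 to compound 2 (0.33 log units; beyond the scatter) was modest, only a small shift in either direction is expected, and the step from compound 2 to compound 3 is estimated as a 1.4-fold higher number from compound 2 to compound 3 (0.16 log units; within the scatter). Compound 3 is therefore expected to give about 100 nM in this assay, with a likely range from 30 nM to 400 nM.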

Compound 3, half-maximal effective concentration: 208 nM
Estimate against measurement, compound 3: 2.1-fold (0.32 log units) below, and the stated range covers the measured number.
By their numbers in this assay, from the lowest: compound 2; then compounds 1 and 3 (each within the scatter of the next).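

At this position, on an aromatic carbon para to a large group, a longer outer group with a double bond is accepted, but 2-(4-methoxyphenyl)ethenyl in place of 4-(methylsulfanyl)phenyl gives a 3.0-fold higher number from compound 2 to compound 3 (0.48 log units; beyond the scatter) in this assay. Against 3-ethoxyphenyl, the same group gives a 1.4-fold higher number from compound 1 to compound 3 (0.15 log units; within the scatter), so these two outer groups cannot be told apart here, and among the three compounds only 4-(methylsulfanyl)phenyl stands out, with the lowest number. Nothing shown here explains why these groups differ.

The change from compound 2 to compound 3 swaps sulfur for oxygen and adds the double bond in a single step, so the compounds shown leave open how much each part contributes. They also leave open how a plain 4-methoxyphenyl group, or an outer ring carrying an amine or a carboxylic acid, would compare at this position.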